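Swapping the terminal aryl ring on a picolinamide scaffold

A few compounds are considered here, and "the series" means these few. Any claim that something is new, unique, unknown or untested is made for them only; others in the source may bear on it.

Measured so far:
compound 1 `Cc1cccc(NC(=O)c2cc(-c3cccc(F)c3)ccn2)n1`: 500 nM
compound 2 `Cc1cccc(NC(=O)c2ccc(-c3ccccc3)cn2)n1`: 2800 nM
compound 3 `COc1ccccc1-c1ccc(C(=O)Nc2cccc(C)n2)nc1`: 560 nM

In an assay on membranes from brain for displacement of a labelled ligand from metabotropic glutamate receptor 5 (Rattus norvegicus) (a higher number here means a weaker inhibitor, a lower number a stronger inhibitor), compound 3 gives 560 nM, the second highest of the three numbers; compound 1 sits within the scatter of it, while compound 2 lies well apart, a step of a 5.0-fold lower number from compound 2 to compound 3 (0.70 log units; beyond the scatter). Compound 4 `Cc1cccc(NC(=O)c2ccc(-c3ccccn3)cn2)n1` differs from compound 3 by pyridin-2-yl in place of 2-methoxyphenyl on an aromatic carbon. Only the step from compound 2 to compound 3 bears on this change, and it shows that losing the methoxy group costs potency; how pyridin-2-yl compares with phenyl is not shown by any measured pair. Compound 4 is therefore expected to move back toward compound 2, a step of a 3.6-fold higher number from compound 3 to compound 4 (0.55 log units; beyond the scatter) in this assay. The estimate for compound 4 is 2000 nM, with a range from 600 nM to 6500 nM.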

Compound 4, inhibition constant: 100 nM
Compound 4: the middle estimate sits 20-fold (1.30 log units) above what was measured; the whole stated range lies above it.
By their numbers in this assay, from the lowest: compound 4; then compounds 1 and 3 (each within the scatter of the next); then compound 2.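

In this assay, within the data shown here, the terminal ring at this position proves far more sensitive than the earlier compounds showed, with a 28-fold lower number from compound 2 to compound 4 (1.45 log units; beyond the scatter) when pyridin-2-yl replaces phenyl and a 5.6-fold lower number from compound 3 to compound 4 (0.75 log units; beyond the scatter) when it replaces 2-methoxyphenyl on the same carbon. A methoxy group is therefore not needed for a lower number, since a ring nitrogen in the terminal ring also gives one. The compounds shown leave open whether pyridin-3-yl would do the same, or whether an added methoxy or amine on the pyridin-2-yl ring would lower the number further. No measurement available here accounts for the gain.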